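Weak Inhibitors Around a Shared Triaryl Core

The source may report more compounds than this note shows. Statements on the series, on what has been measured and on what is new or still open speak of the compounds shown alone.

Compound 3 `COc1ccc(C(OCc2ccc(C)cc2)c2cccc3ccccc23)c(OC)c1OC` stands at the edge of what can be measured: in a functional assay on THP-1 cells (Homo sapiens) for inhibition, read by sulforhodamine B assay, with a stated time of 48 h (a lower number here means a stronger inhibitor, a higher number a weaker inhibitor), compound 3 gives > 20000 nM, which is a limit of the assay and not a number. Compound 1 `COc1ccc(C(c2ccc(OCCO)cc2)c2cccc3ccccc23)c(OC)c1OC` gives 16600 nM in this assay. Compound 2 `COc1ccc(C(c2ccccc2O)c2cccc3ccccc23)c(OC)c1OC` in this assay gives > 20000 nM, again a limit. The measured steps are an at least 1.2-fold higher number from compound 1 to compound 3 (0.08 log units; that floor lies within the scatter), an at least 1.2-fold higher number from compound 1 to compound 2 (0.08 log units; that floor lies within the scatter) and a step that the two limits leave unreadable from compound 2 to compound 3, and their readability is shaped by the limit of > 20000 nM in this assay, at which 2 of the 3 values shown sit. Compound 4 `COc1ccc(C(c2ccc(OCC(=O)O)cc2)c2cccc3ccccc23)c(OC)c1OC` arises from compound 3 by 4-(carboxymethoxy)phenyl in place of (4-methylbenzyl)oxy on a saturated chain carbon bound to two aromatic carbons. The entering group resembles the 4-(2-hydroxyethoxy)phenyl of compound 1, whose value in this assay is 16600 nM, so compound 4 is expected to come out at a similarly weak level. The expected step is a number no higher from compound 3 to compound 4 (the limit leaves the size open), read only against a limit. Compound 4 is estimated at 20000 nM, within a range from 8000 nM to 50000 nM.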

Compound 4, half-maximal inhibitory concentration: > 20000 nM
Compound 4: a limit, no number; the forecaster's own chance of this, stated with the estimate: 50%; the middle value sits exactly at the limit.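

Carboxy in place of hydroxymethyl on a saturated chain carbon bound to an oxygen on an aromatic ring gives an at least 1.2-fold higher number from compound 1 to compound 4 (0.08 log units; that floor lies within the scatter), so this change at the chain end shows no readable shift in this assay. The value of compound 4 is a limit of the assay and not a number. The steps to compound 4 from compound 2 and from compound 3 cannot be read, because these values sit at one limit: the limit of > 20000 nM in this assay, at which 3 of the 4 values shown sit.

As far as these compounds go, whether an amine or an amide at this chain end, or a longer chain, would give a measurable value remains open.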